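Swapping the para substituent on the benzylamine arm

This account rests on a few compounds, and the source may have more. Where it says the series, first, only, none or still open, it means among the compounds named here.

In a functional assay on HEK293 cells for agonist activity at G-protein coupled receptor 39 (Mus musculus), read by inositol phosphate accumulation (on this read-out lower numbers stand for an effect already at smaller amounts and higher numbers for an effect only at larger amounts of compound), compound 1, `CNc1nc(NCc2ccc(OC(F)(F)F)cc2)cc(-c2ccccn2)n1`, gives 7 nM. Among the three measured compounds it holds the second highest number. Compound 3, `CNc1nc(NCc2ccc(Cl)cc2Cl)cc(-c2ccccn2)n1`, gives 0.5 nM in this assay, a lower number than compound 1 and beyond the scatter. Compound 2, `c1ccc(-c2cc(NCC3CC3)ncn2)nc1`, gives 10000 nM in this assay, a far higher number than compound 1 and also beyond the scatter. Compound 4, `CNc1nc(NCc2ccc(NC(C)=O)cc2)cc(-c2ccccn2)n1`, has not yet been measured. It differs from compound 1 in one spot: acetamido in place of trifluoromethoxy on an aromatic carbon. Within the data shown here, no pair of measured compounds differs in just this one place, so nothing here tells directly how large such a swap runs. Among the measured compounds shown here, the two measured neighbours of compound 1 show only that changes on that benzyl ring can move the number in either direction by a good margin. With no closer guide, a moderate step toward higher numbers, beyond the scatter, is expected from compound 1 to compound 4, namely a 4.3-fold higher number from compound 1 to compound 4 (0.63 log units; beyond the scatter). Compound 4 is therefore estimated at 30 nM, with a range from 7 nM to 150 nM.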

Compound 4, half-maximal effective concentration: 2 nM
Estimate against measurement, compound 4: 15-fold (1.18 log units) above, outside the stated range (below it).
By their numbers in this assay, from the lowest: compound 3; then compound 4; then compound 1; then compound 2.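

Among these compounds, putting acetamido in place of trifluoromethoxy on this aromatic carbon gives a 3.5-fold lower number from compound 1 to compound 4 (0.54 log units; beyond the scatter) in this assay, the first reading of a change made at this one spot alone. The spot therefore accepts a group with a different make-up, including a hydrogen-bond donor that trifluoromethoxy lacks, and the number still moves down, beyond the scatter. Nothing on hand explains why this swap lowers the number.

Still open, on these data alone, is whether other groups on this carbon, such as a free amine, a carboxylic acid or a longer amide chain, would keep the number this low. As far as these compounds go, it is also open whether the same swap would give a step of similar size on a ring carrying further substituents.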